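Sulfonyl substituent variation on the shared core: toward compound 4

This account rests on a few compounds, and the source may have more. Where it says the series, first, only, none or still open, it means among the compounds named here.

Measured compounds:
- compound 1 `O=C([C@@H]1CCCN(S(=O)(=O)c2ccc(S(=O)(=O)N3CC[C@@H](O)C3)cc2)C1)N1CCC(F)(F)CC1`: 210 nM
- compound 2 `O=C([C@@H]1CCCN(S(=O)(=O)c2ccc(S(=O)(=O)C3COC3)cc2)C1)N1CCC(F)(F)CC1`: 110 nM
- compound 3 `CC(C)CS(=O)(=O)c1ccc(S(=O)(=O)N2CCC[C@@H](C(=O)N3CCC(F)(F)CC3)C2)cc1`: 80 nM

All three share the core and differ only in the group on the sulfonyl sulfur attached to the aromatic carbon. In a functional assay on MIA PaCa-2 cells (Homo sapiens) for inhibition, read by MTT assay, with a stated time of 7 days (on this read-out lower numbers stand for stronger inhibition and higher numbers for weaker inhibition), compound 3 gives the lowest number of the three; its gap to compound 2 is within the scatter, so the two cannot be ordered, while the step of a 2.6-fold lower number from compound 1 to compound 3 (0.42 log units; beyond the scatter) is beyond the scatter. The step of a 1.9-fold lower number from compound 1 to compound 2 (0.28 log units; within the scatter) is within the scatter, as is a 1.4-fold lower number from compound 2 to compound 3 (0.14 log units; within the scatter).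

Compound 4 `CC(C)NS(=O)(=O)c1ccc(S(=O)(=O)N2CCC[C@@H](C(=O)N3CCC(F)(F)CC3)C2)cc1` is not yet measured. The change is isopropylamino in place of isobutyl on a sulfonyl sulfur. Among the measured compounds shown here, no measured step introduces isopropylamino. For the measured compounds named here, the nearest guidance is compound 1, the only analogue whose sulfonyl substituent carries a hydrogen-bond donor, and it gives the highest number because of a 2.6-fold lower number from compound 1 to compound 3 (0.42 log units; beyond the scatter); compound 2, with no donor, sits within the scatter of compound 3. A small step toward a higher number is therefore expected, likely within the scatter.

For compound 4 the expected step is a 1.6-fold higher number from compound 3 to compound 4 (0.21 log units; within the scatter). The estimate for compound 4 is 130 nM, expected to fall between 50 nM and 350 nM.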

Compound 4, half-maximal inhibitory concentration: 350 nM
For compound 4 the middle estimate is 2.7-fold (0.43 log units) below the measured one, and the stated range covers the measured number.
By their numbers in this assay, from the lowest: compounds 3, 2, 1 and 4 (each within the scatter of the next, the first and the last beyond it).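

In this assay, isopropylamino in place of isobutyl on a sulfonyl sulfur leaves the heavy-atom count unchanged and adds one hydrogen-bond donor, yet gives a 4.4-fold higher number from compound 3 to compound 4 (0.64 log units; beyond the scatter) (the position therefore responds to a change that adds no heavy atoms). Against oxetan-3-yl the same group gives a 3.2-fold higher number from compound 2 to compound 4 (0.50 log units; beyond the scatter) (also a real separation), whereas against 3-hydroxypyrrolidin-1-yl it gives a 1.7-fold higher number from compound 1 to compound 4 (0.22 log units; within the scatter) and those two cannot be ordered. Compound 4 lies beyond the scatter of both donor-free analogues, while compound 1 lies beyond the scatter of compound 3 only, so compound 2 goes against a clean split by donor.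

On these data alone, whether the step follows the nitrogen with its hydrogen or the change of chain stays open, and dimethylamino or isopropyl on the same sulfur would separate the two. No measurement in hand accounts for the step.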